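The source may hold more compounds than are shown below. What is called first, only, known or untested is meant among the compounds shown, and "the series" means these compounds.

Measured compounds in a functional assay on the whole organism (artery, strain albino) with Rattus norvegicus as the target, with a stated time of 120 min, at a dose of 10 mg/kg by the oral route; a lower number here means less inhibition, a higher number more inhibition at the dose given (going by the name of the read-out):
- compound 1, `COc1ccc(C2N=C(SCc3cccc(Cl)c3)NC(C)=C2C(=O)Nc2ccc(F)cc2)cc1OC`: 10.8%
- compound 2, `COc1ccc(C2N=C(SCc3ccc(F)cc3)NC(C)=C2C(=O)Nc2ccc(F)cc2)cc1OC`: 15.5%
- compound 3, `CC1=C(C(=O)Nc2ccc(F)cc2)C(c2ccc([N+](=O)[O-])cc2)N=C(SCc2cccc(Cl)c2)N1`: 9.8%

Compound 3 gives the lowest of the three numbers in this assay, but its gap to compound 1 and its gap to compound 2 both lie within the scatter, so no rank among the three is claimed. The single-place steps recorded so far are a number 4.7 percentage points higher from compound 1 to compound 2 (within the scatter) and a number 1 percentage points lower from compound 1 to compound 3 (within the scatter); neither reaches beyond the scatter.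

Compound 4, `CC1=C(C(=O)Nc2ccc(F)cc2)C(c2ccc([N+](=O)[O-])cc2)N=C(SCc2ccc(F)cc2)N1`, is not yet measured. Its difference from compound 3: 4-fluorophenyl in place of 3-chlorophenyl on a saturated chain carbon bound to a sulfur. The same exchange on the saturated chain carbon bound to a sulfur is already covered by the step of a number 4.7 percentage points higher from compound 1 to compound 2 (within the scatter), in a compound carrying 3,4-dimethoxyphenyl rather than 4-nitrophenyl on the saturated ring carbon; that step stayed within the scatter. Nothing in the data indicates that the 4-nitrophenyl series should respond differently.

Compound 4 is therefore expected to sit close to compound 3, with a step of a number 4.2 percentage points higher from compound 3 to compound 4 (within the scatter), which is inside the scatter. The estimate for compound 4 in this assay is 14%, with a range from 4% to 24%.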

Compound 4, a percentage reported as inhibition, in the whole organism at one dose (the size of the read-out at that dose, not a potency): 17%
Compound 4: the middle estimate sits 3 percentage points below what was measured; measured number inside the range.
By their numbers in this assay, from the lowest: compounds 3, 1, 2 and 4 (each within the scatter of the next).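

In this assay, 4-fluorophenyl in place of 3-chlorophenyl on a saturated chain carbon bound to a sulfur has now been read on a second core, giving a number 7.2 percentage points higher from compound 3 to compound 4 (within the scatter); like the first reading, this stays inside the scatter, so no effect of the change is established at this position. The two readings agree across the cores: the same change on two cores in this assay, a number 4.7 percentage points higher (within the scatter) from compound 1 to compound 2 and a number 7.2 percentage points higher (within the scatter) from compound 3 to compound 4, 2.5 percentage points apart, within the scatter of two such steps. The change from 3,4-dimethoxyphenyl to 4-nitrophenyl on the saturated ring carbon, now also read with 4-fluorophenyl on the chain carbon, gives a number 1.5 percentage points higher from compound 2 to compound 4 (within the scatter), and its two readings agree as well: the same change on two cores in this assay, a number 1 percentage points lower (within the scatter) from compound 1 to compound 3 and a number 1.5 percentage points higher (within the scatter) from compound 2 to compound 4, 2.5 percentage points apart, within the scatter of two such steps.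

From the compounds shown here alone, only halogen-bearing phenyl groups appear on the saturated chain carbon bound to a sulfur, so the outcome with a carboxylic acid or an amine there remains open. Also open, going by these compounds, is whether an unsubstituted phenyl or a pyridine on the saturated ring carbon would give a step beyond the scatter.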